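The source may hold more compounds than are shown below. What is called first, only, known or untested is meant among the compounds shown, and "the series" means these compounds.

Compound 1 `CCc1ccc(C(=O)/C=C/C(=O)O)cc1` gives 5530 nM
Compound 2 `Cc1ccc(C(=O)/C=C/C(=O)O)c(Cl)c1` gives 14600 nM

Both numbers come from a functional assay on K562 cells (Homo sapiens) for inhibition, read by MTT assay, with a stated time of 72 h (on this read-out lower numbers stand for stronger inhibition and higher numbers for weaker inhibition), and are all that has been measured so far. Compound 2 with 14600 nM stands highest of the two, and its gap to compound 1 lies beyond the usual scatter of repeated measurements. The two compounds differ in more than one place, so their gap cannot be tied to any single change.

Compound 3 `O=C(O)/C=C/C(=O)c1ccc(Cl)cc1Cl` has not yet been measured. It differs from compound 2 in one place, as chloro in place of methyl on an aromatic carbon sets out: chloro in place of methyl on an aromatic carbon. In this assay, within the data shown here, no measured pair shows what this swap does, so there is little to support a large move in either direction, and no step beyond the scatter is expected. The estimated step of a 1.5-fold lower number from compound 2 to compound 3 (0.16 log units; within the scatter) stays within that scatter. For compound 3 the expected value is 10000 nM with a range from 4000 nM to 25000 nM as an estimate.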

Compound 3, half-maximal inhibitory concentration: 58500 nM
Compound 3: the middle estimate sits 5.9-fold (0.77 log units) below what was measured; measured number above the stated range.
By their numbers in this assay, from the lowest: compound 1; then compound 2; then compound 3.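

In this assay, among these compounds, chloro in place of methyl on the aromatic carbon that lies meta to a chloro group and para to a group of 7 heavy atoms gives a 4.0-fold higher number from compound 2 to compound 3 (0.60 log units; beyond the scatter) and lies beyond the scatter, the first step in this assay that can be tied to a single change. This position therefore tells apart two groups that match in what is counted here, with one heavy atom each, no hydrogen-bond donors or acceptors and no net charge, and methyl goes with the lower number and so the stronger inhibition. No measurement of any property bears on this step, so the data give no reason for it.

Methyl and chloro are the only two groups compared at this position, so it remains open how a methoxy group or an amine there would compare with either. A single pair also cannot show whether the same swap would move the number in the same direction on another carbon of the ring or on a different core.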